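The source may report more compounds than this note shows. Statements on the series, on what has been measured and on what is new or still open speak of the compounds shown alone.

Measured so far in a functional assay on MCF7 cells (Homo sapiens) for cytotoxicity, read by sulforhodamine B assay, with a stated time of 24 h; on this read-out higher numbers stand for weaker inhibition and lower numbers for stronger inhibition:
Compound 1 `N#CCC(=O)N/N=C1\C(=O)Nc2ccc(S(=O)(=O)N3CCOCC3)cc21` gives 27700 nM
Compound 2 `O=C1Nc2ccc(S(=O)(=O)N3CCOCC3)cc2/C1=N/NS(=O)(=O)c1ccccc1` gives 25300 nM

On these two numbers, compound 2 at 25300 nM cannot be told apart from compound 1. Within the data shown here, compound 3 `O=C1Nc2ccc(S(=O)(=O)N3CCOCC3)cc2/C1=N/c1ccc(Cl)cc1` carries 4-chlorophenyl in place of (phenylsulfonyl)amino on a double-bonded nitrogen as its one change. Only a 1.1-fold lower number from compound 1 to compound 2 (0.04 log units; within the scatter) bears on this, and that step kept the amine nitrogen that compound 3 loses, so it guides only loosely. No step beyond the scatter is therefore expected in this assay and the estimated change is a 1.3-fold lower number from compound 2 to compound 3 (0.10 log units; within the scatter) with wide uncertainty. The estimate for compound 3 is 20000 nM with 7000 nM to 60000 nM as its expected range.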

Compound 3, half-maximal inhibitory concentration: 44300 nM
Beside the measured number, compound 3's estimate is 2.2-fold (0.35 log units) below it; low and high end bracket the measured number.
By their numbers in this assay, from the lowest: compounds 2, 1 and 3 (each within the scatter of the next).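

In this assay, 4-chlorophenyl on the double-bonded nitrogen gives (a 1.8-fold higher number from compound 2 to compound 3 (0.24 log units; within the scatter)) and (a 1.6-fold higher number from compound 1 to compound 3 (0.20 log units; within the scatter)). This position therefore accepts a ring attached directly in place of an amino-linked group, and losing the hydrogen-bond donor and acceptors of (phenylsulfonyl)amino moves the number no further than the scatter. Nothing available here explains these numbers. Going by these compounds, whether a carboxylic acid on that ring, or a longer alkyl chain in its place, would give a step beyond the scatter remains open.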